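The source may report more compounds than this note shows. Statements on the series, on what has been measured and on what is new or still open speak of the compounds shown alone.

Measured so far, in a functional assay on RS4-11 cells (Homo sapiens) for inhibition, read by CCK-8 assay, with a stated time of 48 h; on this read-out lower numbers stand for stronger inhibition and higher numbers for weaker inhibition:
compound 1, `COc1ccc(Oc2ccccc2-c2ccsc2S(=O)(=O)N2CCN(C(=O)Nc3ccc([N+](=O)[O-])cc3)CC2)cc1OC`: > 50000 nM.
compound 2, `COc1ccc(Oc2ccccc2-c2ccsc2S(=O)(=O)N2CCN(C(=O)Nc3ccc(F)cc3)CC2)cc1OC`: 14900 nM.
compound 3, `COc1ccc(Oc2ccccc2-c2ccsc2S(=O)(=O)N2CCN(C(=S)Nc3ccc(Cl)cc3)CC2)cc1OC`: > 50000 nM.

Compound 1 has a value that is a limit of this assay and not a number; compound 1 gives > 50000 nM. The value of compound 3, > 50000 nM, is likewise a limit (the limit of > 50000 nM in this assay, at which 2 of the 3 values shown sit). Going by the values given here, compound 2 alone gives a number, 14900 nM, and the step of an at least 3.3-fold lower number from compound 1 to compound 2 (0.52 log units; beyond the scatter) is the one readable change, while an at least 3.3-fold higher number from compound 2 to compound 3 (0.52 log units; beyond the scatter) runs the other way and a step that the two limits leave unreadable from compound 1 to compound 3.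

Compound 4, `O=C(Nc1ccc([N+](=O)[O-])cc1)N1CCN(S(=O)(=O)c2sccc2-c2ccccc2Oc2ccc(O)c(O)c2)CC1`, is not yet measured. It differs from compound 1 in 3,4-dihydroxyphenyl in place of 3,4-dimethoxyphenyl on an oxygen on an aromatic ring; the 3,4-dimethoxyphenyl leaves and a 3,4-dihydroxyphenyl enters, on an oxygen on an aromatic ring. None of the three measured steps touches this part of the shared core; all three change the group on the amine nitrogen in the ring. Among the compounds with values here, there is thus no measured step to set a size or direction for this assay, and compound 1 itself sits at a limit. The expectation for compound 4 is therefore a value near the limit of compound 1, with a wide range: 50000 nM (15000 nM to 150000 nM). The step this estimate means, a number no higher from compound 1 to compound 4 (the limit leaves the size open), is expected to stay within the scatter.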

Compound 4, half-maximal inhibitory concentration: 14300 nM
Beside the measured number, compound 4's estimate is 3.5-fold (0.54 log units) above it; the measured number lies below the stated range.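

In this assay, going by these compounds alone, the exchange of 3,4-dimethoxyphenyl for 3,4-dihydroxyphenyl gives an at least 3.4-fold lower number from compound 1 to compound 4 (0.54 log units; beyond the scatter) and is the first readable step made away from the amine nitrogen in the ring. The group on that nitrogen stays the same across this pair, so a change on the oxygen on an aromatic ring is enough on its own to move the number beyond the scatter. The full size of the step cannot be read, as the value of compound 1 is a limit of the assay and not a number: the limit of > 50000 nM in this assay, at which 2 of the 4 values shown sit.

As far as these compounds go, it remains open whether a phenyl carrying a single hydroxy group, or one carrying an amino group, would give a similar step. Within the data shown here, it is also open whether the same exchange would move the number when the group on the amine nitrogen is the one in compound 2.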